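A few compounds are considered here, and "the series" means these few. Any claim that something is new, unique, unknown or untested is made for them only; others in the source may bear on it.

Compound 1, `CS(=O)(=O)c1ccc(C(=O)Nc2ccc(Cl)c(-c3nnc4c(Cl)cccn34)c2)c(Cl)c1`: in a functional assay on U-251 cells (Homo sapiens) for antiproliferative activity, read by MTT assay, with a stated time of 72 h (a lower number here means a stronger inhibitor, a higher number a weaker inhibitor), compound 1 gives 44600 nM.
Compound 2, `O=C(Nc1ccc(Cl)c(-c2nnc3c(Cl)cccn23)c1)c1cccnc1Cl`: in this assay compound 2 reaches only the limit > 100000 nM, a bound and not a number.
Compound 3, `O=C(Nc1ccc(Cl)c(-c2nnc3c(Cl)cccn23)c1)c1ccccc1`: in this assay compound 3 gives 73500 nM.

Among the two numbers, compound 3 stands highest, and its gap to compound 1 lies within the scatter, so the two cannot be ordered. Among the compounds with values here, the only measured step, an at least 1.3-fold lower number from compound 2 to compound 3 (0.13 log units; that floor lies within the scatter), replaced a 2-chloropyridin-3-yl on the carbonyl carbon with a plain phenyl, and its floor lies within the scatter; at the same time it moved away from a limit, (the limit of > 100000 nM in this assay, at which 1 of the 3 values shown sits), so its true size is unknown.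

Compound 4, `O=C(Nc1ccc(Cl)c(-c2nnc3c(Cl)cccn23)c1)c1ccccc1Cl`, carries the change (chloro in place of hydrogen on an aromatic carbon), which puts a chloro back onto the ring beside the carbonyl, ortho to a large group. Since the step from compound 2 to compound 3 removed a chloro-bearing ring and gave a number, the reverse-looking change is expected to give no step beyond the scatter, or a somewhat higher number, a 1.2-fold higher number from compound 3 to compound 4 (0.09 log units; within the scatter). Compound 4 is therefore expected to give about 90000 nM, within 40000 nM to 200000 nM.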

Compound 4, half-maximal inhibitory concentration: > 100000 nM
Compound 4: a limit, no number (the forecaster's own chance of this, stated with the estimate: 40%); at least 1.1-fold (0.04 log units) between middle value and limit.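

Adding the chloro to the phenyl of compound 3 gives an at least 1.3-fold higher number from compound 3 to compound 4 (0.13 log units; that floor lies within the scatter), so in this assay this change shows no gain in activity, and any loss cannot be told from the scatter. Within the data shown here, the clearer information concerns the methylsulfonyl group: with the 2-chlorophenyl framework kept, hydrogen in its place gives an at least 2.2-fold higher number from compound 1 to compound 4 (0.35 log units; beyond the scatter), the first step in this set that lies beyond the scatter. Compound 4 reaches only a limit, not a number, so the true size of both steps is unknown, and the step from compound 2 to compound 4 cannot be read: the limit of > 100000 nM in this assay, at which 2 of the 4 values shown sit.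

Open, as far as these compounds go, is whether a methoxy or an amine in place of this chloro would bring a number below the limit. Also open, from the compounds shown here alone, is whether a carboxylic acid or a nitrile in place of the methylsulfonyl would keep the lower number of compound 1.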